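From 2,3-dichlorophenyl to 2-chlorophenyl: one chlorine fewer

The source may hold more compounds than are shown below. What is called first, only, known or untested is meant among the compounds shown, and "the series" means these compounds.

The series shares one core and a chain ending in a substituted phenyl ring. The measured set comprises compound 1 (`COc1ccc(OCCCON2C(N)=NC(N)=NC23CCOCC3)cc1`), compound 2 (`NC1=NC2(CCOCC2)N(OCCCOc2ccc(Cl)cc2)C(N)=N1`) and compound 3 (`NC1=NC2(CCOCC2)N(OCCCOc2cccc(Cl)c2Cl)C(N)=N1`). In a functional assay on HepG2 cells (Homo sapiens) for antiproliferative activity, read by MTT assay, with a stated time of 72 h (a lower number here means a stronger inhibitor, a higher number a weaker inhibitor), compound 1 is recorded as "not determined" (no result reported), and compound 2 as "not determined" (no result reported). Among the compounds with values here, compound 3 gives 330 nM, the only number, so it cannot yet be ranked against any other compound.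

Compound 4 (`NC1=NC2(CCOCC2)N(OCCCOc2ccccc2Cl)C(N)=N1`) departs from compound 3 in one place: hydrogen in place of chloro on an aromatic carbon. This is hydrogen in place of chloro on an aromatic carbon, ortho to a chloro group and meta to a large group, so that 2,3-dichlorophenyl becomes 2-chlorophenyl.

Within the data shown here, no two measured compounds differ in a single place, so the series offers no direct gauge for this step in this assay. Among the measured compounds shown here, the only anchor is compound 3 at 330 nM. The expected step, a 1.5-fold higher number from compound 3 to compound 4 (0.18 log units; within the scatter), is small, close to the usual scatter and leaning towards weaker inhibition. For compound 4 the estimated value is 500 nM, with an expected range of 130 nM to 1800 nM.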

Compound 4, half-maximal inhibitory concentration: 1750 nM
Compound 4: the middle estimate sits 3.5-fold (0.54 log units) below what was measured; low and high end bracket the measured number.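

In this assay, within the data shown here, taking the chloro group off the aromatic carbon, so that 2,3-dichlorophenyl becomes 2-chlorophenyl, gives a 5.3-fold higher number from compound 3 to compound 4 (0.72 log units; beyond the scatter) and is the first step that can be read directly. With the shared core and the chain unchanged, this one chlorine on the carbon ortho to a chloro group and meta to a large group accounts for a difference beyond the scatter, in the direction of weaker inhibition, so this position on the ring is not indifferent in this assay. Nothing at hand bears on the reason for the size of this step.

Among these compounds, compound 1 and compound 2 carry no number, so steps that involve them cannot be read, and the single step rests on one pair of compounds. Going by these compounds, whether a fluoro, methyl or methoxy group on the same aromatic carbon would hold the level of compound 3 remains open, as does the outcome of removing the other chloro group from the 2,3-dichlorophenyl ring instead.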